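This account rests on a few compounds, and the source may have more. Where it says the series, first, only, none or still open, it means among the compounds named here.

Of the compounds shown here, two have been measured in an assay on cells for inhibition of histone-lysine N-methyltransferase EZH2 (Homo sapiens), read by ELISA, with a stated time of 72 h; a higher number here means a weaker inhibitor, a lower number a stronger inhibitor. Compound 1, `Cc1cc(C)c(CN2CCc3ccc(O[C@@H]4CCOC4)c(Cl)c3C2=O)c(=O)[nH]1`, gives 796 nM. Compound 2, `Cc1cc(C)c(CN2CCc3c(Cl)cc(-c4c(C)n[nH]c4C)c(Cl)c3C2=O)c(=O)[nH]1`, gives 502 nM. These two values lie within the usual scatter of repeated measurements, so on the numbers shown neither compound can be called the more potent; compound 2 simply sits alongside compound 1.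

Compound 3, `Cc1cc(C)c(CN2CCc3c(Cl)cc(-c4cn[nH]c4C)c(Cl)c3C2=O)c(=O)[nH]1`, has not yet been measured. It differs from compound 2 in a single place: hydrogen in place of methyl on an aromatic carbon. Within the data shown here, no measured pair in this set shows the effect of such a change, so the expectation rests on its small size alone. A step of about a 1.4-fold higher number from compound 2 to compound 3 (0.14 log units; within the scatter) is expected, a shift no larger than the scatter itself. Compound 3 is therefore estimated at 700 nM, with a plausible range from 250 nM to 2000 nM.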

Compound 3, half-maximal inhibitory concentration in the histone-lysine N-methyltransferase EZH2 assay: 873 nM
Estimate against measurement, compound 3: 1.2-fold (0.10 log units) below; the range from low to high includes it.
By their numbers in the histone-lysine N-methyltransferase EZH2 assay, from the lowest: compounds 2, 1 and 3 (each within the scatter of the next).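

Among these compounds, this pair is the first in the set to differ in one place only, so the methyl on the 3,5-dimethyl-1H-pyrazol-4-yl group can now be judged on its own; in a physicochemical assay for lipophilicity, at pH 7.4 (on this read-out lower numbers stand for lower lipophilicity and higher numbers for higher lipophilicity), compound 2 gives 3.4 and compound 3 gives 3.1. In the histone-lysine N-methyltransferase EZH2 assay, replacing it with hydrogen gives a 1.7-fold higher number from compound 2 to compound 3 (0.24 log units; within the scatter), and in the physicochemical assay the same replacement gives a number 0.30 log units lower from compound 2 to compound 3 (within the scatter), so neither read-out separates the two compounds and this methyl is not required for the activity seen here. No available evidence bears on why the numbers fall as they do.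

Still open, as far as these compounds go, is what the remaining methyl on the ring contributes, and what a larger group on this carbon, such as an ethyl, a methoxy or an amine, would do to either number. Among the compounds shown here, with only one pair carrying this change, nothing shows whether it would read the same on another core.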